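A Nitro Group Enters the Aniline Ring of the Shared Core

This account rests on a few compounds, and the source may have more. Where it says the series, first, only, none or still open, it means among the compounds named here.

Compound 1 `CCN(CC)c1nc(Nc2ccc(F)cc2)nc(OC(C(F)(F)F)C(F)(F)F)n1`: 700 nM
Compound 2 `CCN(CC)c1nc(Nc2ccc3cn[nH]c3c2)nc(OC(C(F)(F)F)C(F)(F)F)n1`: 900 nM
Compound 3 `CCN(CC)c1nc(Nc2ccccc2)nc(OCC(F)(F)C(F)F)n1`: 2000 nM

Of the compounds shown here, three share one core and have been measured in an assay on cells for activation of Cystic fibrosis transmembrane conductance regulator (Homo sapiens), read by fluorescence, with stated times of 10 min and 12 s; on this read-out higher numbers stand for an effect only at larger amounts of compound and lower numbers for an effect already at smaller amounts. Compound 3, which carries an unsubstituted phenyl on the nitrogen and a tetrafluoropropyl ether, shows the highest number of the three; the values of compound 2 and of compound 1 both lie below it by more than the scatter.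

The next compound, compound 4 `CCN(CC)c1nc(Nc2cccc([N+](=O)[O-])c2)nc(OCC(F)(F)C(F)F)n1`, differs from compound 3 by a single change: nitro in place of hydrogen on an aromatic carbon.

Going by the values given here, only one measured step exists, a 1.3-fold higher number from compound 1 to compound 2 (0.11 log units; within the scatter), and it alters the aryl group as a whole rather than adding a substituent to a phenyl ring. Among the compounds with values here, no measured pair shows what a nitro group on this ring does, so the step to compound 4 rests on no direct precedent. Within the data shown here, the one aryl change that was measured stayed within the scatter, which gives no reason to expect a large move in either direction.

Compound 4 is therefore estimated at 1600 nM, with a range from 500 nM to 5000 nM. The expected step is a 1.3-fold lower number from compound 3 to compound 4 (0.10 log units; within the scatter), which stays within the scatter.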

Compound 4, half-maximal effective concentration: 1200 nM
The estimate for compound 4 lay 1.3-fold (0.12 log units) above the measured number, within the range that was stated.
By their numbers in this assay, from the lowest: compounds 1, 2, 4 and 3 (each within the scatter of the next, the first and the last beyond it).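

In this assay, going by these compounds alone, the change from phenyl to 3-nitrophenyl gives a 1.7-fold lower number from compound 3 to compound 4 (0.22 log units; within the scatter) and is the first measured case in which a substituent is added to a phenyl ring, rather than one aryl group being replaced as a whole. A nitro group, with its 3 heavy atoms, 2 hydrogen-bond acceptors and no net charge, can therefore sit on this aromatic carbon, meta to a large group, with the number staying within the scatter of that of the unsubstituted phenyl compound, and both aryl changes measured so far, each on its own ether, stay within the scatter. The data offer no explanation for this outcome.

On these data alone, what an amine, a carboxylic acid or a methoxy group would give on this same aromatic carbon remains open, so this single nitro result does not show how widely the place accepts other groups. As far as these compounds go, it is also open whether nitro in place of hydrogen would give a similar step on the ether carried by compound 1, or at another carbon of the ring.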